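Replacing Butyl with 1,3-Thiazol-2-yl on the Amide Nitrogen

The compounds below may be only part of what the source reports. "The series", "measured", "known", "first", "only" and "open" are said of these compounds alone.

Of the compounds shown here, three built on one shared core have been measured in a functional assay on the whole organism for inhibition, with Rattus norvegicus as the target, read by paw edema, at a dose of 100 mg/kg by the oral route; a higher number here means more inhibition at the dose given (going by the name of the read-out), a lower number less inhibition. Compound 1 `CCOC(=O)c1c(O)c2cccnc2n(-c2ccccc2)c1=O`, which carries the ethoxy group on its carbonyl carbon, gives 23.5%. Compound 2 `CCCCNC(=O)c1c(O)c2cccnc2n(-c2ccccc2)c1=O`, with butylamino in that place, gives 12.8%, and compound 3 `Cc1cccc(NC(=O)c2c(O)c3cccnc3n(-c3ccccc3)c2=O)c1`, with (3-methylphenyl)amino there, gives 14.2%. Going by the values given here, compound 2 thus stands at the lowest of the three numbers, though its gap to compound 3 is within the scatter; only the step of a number 10.7 percentage points lower from compound 1 to compound 2 (beyond the scatter) lies beyond it, whereas a number 9.3 percentage points lower from compound 1 to compound 3 (within the scatter) does not.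

Compound 4 `O=C(Nc1nccs1)c1c(O)c2cccnc2n(-c2ccccc2)c1=O` arises from compound 2 by one change: 1,3-thiazol-2-yl in place of butyl on an amide-type nitrogen. Among the compounds with values here, the single measured step that bears on this is a number 1.4 percentage points higher from compound 2 to compound 3 (within the scatter), in which a ring also took the place of the same butyl group and the number barely moved. On that basis no step beyond the scatter is expected in this assay in either direction. Compound 4 is therefore estimated to give 15%, somewhere between 5% and 28%. The step this implies is expected to be a number 2.2 percentage points higher from compound 2 to compound 4 (within the scatter).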

Compound 4, a percentage reported as inhibition, in the whole organism at one dose (the size of the read-out at that dose, not a potency): 4.6%
Compound 4: middle estimate off by 10.4 percentage points, on the high side; measured number below the stated range.
By their numbers in this assay, from the lowest: compounds 4, 2, 3 and 1 (each within the scatter of the next, the first and the last beyond it).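

On the amide-type nitrogen, a ring with hetero atoms does not separate from the other two groups in this assay: the result is a number 8.2 percentage points lower from compound 2 to compound 4 (within the scatter) and a number 9.6 percentage points lower from compound 3 to compound 4 (within the scatter), so butyl, 3-methylphenyl and 1,3-thiazol-2-yl cannot be told apart in either single step. The comparison with the ester is clearer, at a number 18.9 percentage points lower from compound 1 to compound 4 (beyond the scatter), which sets (1,3-thiazol-2-yl)amino apart from ethoxy on the carbonyl carbon, as butylamino in compound 2 is set apart, whereas (3-methylphenyl)amino in compound 3 goes against this pattern by staying within the scatter of compound 1. No measurement at hand accounts for these numbers.

As far as these compounds go, whether a pyridin-2-yl ring or a plain phenyl on the amide nitrogen would stand apart from butyl remains open. So does the effect of a free carboxylic acid in place of the ester on the shared core.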